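Amino for Hydroxy on the Aryl Ring of a Lactam Series

The source may hold more compounds than are shown below. What is called first, only, known or untested is meant among the compounds shown, and "the series" means these compounds.

Measured compounds:
compound 1, `COc1ccc([C@@H]2C(c3ccc(C)s3)C(=O)N2c2cc(OC)c(OC)c(OC)c2)cc1`: 250 nM
compound 2, `COc1ccc([C@@H]2C(c3ccoc3)C(=O)N2c2cc(OC)c(OC)c(OC)c2)cc1`: 150 nM
compound 3, `COc1ccc([C@@H]2[C@@H](c3cccs3)C(=O)N2c2cc(OC)c(OC)c(OC)c2)cc1O`: 7 nM

All three were tested in a functional assay on MCF7 cells (Homo sapiens) for antiproliferative activity, read by MTT assay; a higher number here means a weaker inhibitor, a lower number a stronger inhibitor. Compound 3 stands lowest of the three numbers; compound 2 is the nearest to it and compound 1 the furthest, and both gaps lie beyond the scatter of the assay. Within the data shown here, the only step measured so far, a 1.7-fold lower number from compound 1 to compound 2 (0.22 log units; within the scatter), concerns the five-membered ring on the saturated ring carbon and stays within the scatter, so it tells nothing about the part of the molecule that is changed next.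

Compound 4, `COc1ccc([C@@H]2[C@@H](c3cccs3)C(=O)N2c2cc(OC)c(OC)c(OC)c2)cc1N`, differs from compound 3 by one change: amino in place of hydroxy on an aromatic carbon. Among the measured compounds shown here, no measured step bears on this exchange, and nothing among the three compounds shows how this assay responds to a change at that position. The expectation is therefore anchored on compound 3 alone, with a wide range: a small step in the direction of a higher number, of a size not clearly beyond the scatter, is estimated, so that a 2.1-fold higher number from compound 3 to compound 4 (0.33 log units; beyond the scatter) is expected. For compound 4 the estimated value is 15 nM, with a range from 4 nM to 60 nM.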

Compound 4, half-maximal inhibitory concentration: 42 nM
Estimate against measurement, compound 4: 2.8-fold (0.45 log units) below, and the stated range covers the measured number.
By their numbers in this assay, from the lowest: compound 3; then compound 4; then compounds 2 and 1 (each within the scatter of the next).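

In this assay, this aromatic carbon, ortho to a methoxy group, is sensitive to a single-atom exchange: amino in place of hydroxy gives a 6.0-fold higher number from compound 3 to compound 4 (0.78 log units; beyond the scatter). Among these compounds, this is the first measured step that reaches this part of the molecule, since the only earlier step concerned the five-membered ring on the saturated ring carbon and stayed within the scatter. Hydroxy and amino match in the computed counts, each with 1 heavy atom, 1 hydrogen-bond donor, 1 hydrogen-bond acceptor and no net charge, so those counts do not separate the two groups, and nothing available here accounts for the rise in the number.

With only hydroxy and amino compared at this carbon, the compounds shown do not reveal whether hydroxy improves on an unsubstituted carbon or amino worsens it, and a plain hydrogen would help to settle that. As far as these compounds go, a fluorine, a methylamino group or an acetamide at the same carbon also remains open, as does whether the same exchange would give a step of similar size with a furan-3-yl or 5-methylthiophen-2-yl ring on the saturated ring carbon.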